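Dropping the Chlorine from the Benzyl Ring

A few compounds are considered here, and "the series" means these few. Any claim that something is new, unique, unknown or untested is made for them only; others in the source may bear on it.

Compound 1, `O=C(Nc1cccc(Cl)c1)Nc1cc2ncncc2cc1OCc1ccccc1Cl`: 2600 nM
Compound 2, `O=C(Nc1cccc(Cl)c1)Nc1cc2ncncc2cc1OCc1cccc(Cl)c1`: 3300 nM
Compound 3, `O=C(Nc1cccc(F)c1)Nc1cc2ncncc2cc1OCc1cccc(Cl)c1`: 3700 nM

Three compounds with a shared core were tested in a functional assay on GBM1 cells (Homo sapiens) for antiproliferative activity, read by WST assay, with a stated time of 72 h; on this read-out lower numbers stand for stronger inhibition and higher numbers for weaker inhibition. Compound 2 stands second highest of the three numbers, yet both neighbours lie within the scatter: a 1.3-fold higher number from compound 1 to compound 2 (0.10 log units; within the scatter) and a 1.1-fold higher number from compound 2 to compound 3 (0.05 log units; within the scatter). Compound 4, `O=C(Nc1cccc(Cl)c1)Nc1cc2ncncc2cc1OCc1ccccc1`, has not been measured. It differs from compound 2 by hydrogen in place of chloro on an aromatic carbon, which one bond further out reads 3-chlorobenzyl to benzyl. The two measured steps, one exchanging 2-chlorophenyl for 3-chlorophenyl on that chain carbon and one exchanging chloro for fluoro on an aromatic carbon, both stayed within the scatter, so no step beyond the scatter is expected here either. Compound 4 is therefore expected to give 3500 nM, between 1500 nM and 8000 nM. The expected step is a 1.1-fold higher number from compound 2 to compound 4 (0.03 log units; within the scatter).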

Compound 4, half-maximal inhibitory concentration: 5700 nM
For compound 4 the middle estimate is 1.6-fold (0.21 log units) below the measured one; low and high end bracket the measured number.
By their numbers in this assay, from the lowest: compounds 1, 2, 3 and 4 (each within the scatter of the next, the first and the last beyond it).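

In this assay, removing the chloro from the 3-chlorobenzyl group gives a 1.7-fold higher number from compound 2 to compound 4 (0.24 log units; within the scatter), so this loss cannot be told apart from the scatter. Within the data shown here, the same exchange on the 2-chlorophenyl group gives a 2.2-fold higher number from compound 1 to compound 4 (0.34 log units; beyond the scatter), the first step here beyond the scatter, though a modest one, so the ring without chloro is separated only from the 2-chloro compound. Nothing available explains this difference. The compounds shown leave open whether a methoxy group or an amine on this ring would match chloro, or give numbers closer to the unsubstituted benzyl.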